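Compound 3 to compound 4: loss of one methoxy

A few compounds are considered here, and "the series" means these few. Any claim that something is new, unique, unknown or untested is made for them only; others in the source may bear on it.

Measured in a functional assay on MDA-MB-231 cells (Homo sapiens) for antiproliferative activity, read by sulforhodamine B assay, with a stated time of 48 h (on this read-out lower numbers stand for stronger inhibition and higher numbers for weaker inhibition), so far:
- compound 1 `COc1cc(OC)c2sc(-c3ccc(N/C=C\C(=O)c4ccc(OC)c(O)c4)c(C)c3)nc2c1` gives 3100 nM
- compound 2 `COc1cc(OC)c2sc(-c3ccc(N/C=C\C(=O)c4ccc(OC)c([N+](=O)[O-])c4)c(C)c3)nc2c1` gives 10800 nM
- compound 3 `COc1ccc(C(=O)/C=C\Nc2ccc(-c3nc4cc(OC)c(OC)c(OC)c4s3)cc2C)cc1F` gives 2900 nM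

Compound 3 sits within the scatter of compound 1 and beyond the scatter from compound 2. Compound 4 `COc1cc(OC)c2sc(-c3ccc(N/C=C\C(=O)c4ccc(OC)c(F)c4)c(C)c3)nc2c1` has hydrogen in place of methoxy on an aromatic carbon of compound 3 (hydrogen in place of methoxy on an aromatic carbon). Among the compounds with values here, the only measured step, a 3.5-fold higher number from compound 1 to compound 2 (0.54 log units; beyond the scatter) for nitro in place of hydroxy, is a different change and bears only indirectly. Compound 1 and compound 2 share the core of compound 4, and their values show the spread seen on that core. No step beyond the scatter is expected in this assay here, with a slight rise assumed. The estimate means a 1.2-fold higher number from compound 3 to compound 4 (0.08 log units; within the scatter) as the expected step. For compound 4 the expected value is 3500 nM with an estimated range of 1500 nM to 8000 nM for now.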

Compound 4, half-maximal inhibitory concentration: 13300 nM
For compound 4 the middle estimate is 3.8-fold (0.58 log units) below the measured one, and the stated range ends below it.
By their numbers in this assay, from the lowest: compounds 3 and 1 (each within the scatter of the next); then compounds 2 and 4 (each within the scatter of the next).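

In this assay, the methoxy lost here carries weight with fluoro held constant: its removal gives a step beyond the scatter (a 4.6-fold higher number from compound 3 to compound 4 (0.66 log units; beyond the scatter)). On the core without it, fluoro reads level with nitro (a 1.2-fold higher number from compound 2 to compound 4 (0.09 log units; within the scatter)) but sits apart from hydroxy (a 4.3-fold higher number from compound 1 to compound 4 (0.63 log units; beyond the scatter)), so the earlier nitro-hydroxy gap recurs with fluoro on the nitro side. No evidence accounts for these steps.

From the compounds shown here alone, whether loss of this methoxy weighs the same with hydroxy or nitro in place of fluoro remains open. So does how an amine or a chloro group would read at the methoxy position.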